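Chloro for bromo on the indole of a diterpenoid ester

The compounds below may be only part of what the source reports. "The series", "measured", "known", "first", "only" and "open" are said of these compounds alone.

Measured so far in a functional assay on SW1573 cells (Homo sapiens) for inhibition, read by sulforhodamine B assay, with a stated time of 48 h; on this read-out lower numbers stand for stronger inhibition of growth and higher numbers for weaker inhibition of growth:
compound 1, `COC(=O)[C@@]1(C)CCC=C2[C@@H]1CC[C@@H](C)[C@]2(C)Cc1c[nH]c2ccc(Br)cc12`, gives 12000 nM
compound 2, `COC(=O)[C@@]1(C)CCC=C2[C@@H]1CC[C@@H](C)[C@]2(C)Cc1c[nH]c2ccc(Cl)cc12`, gives 11000 nM
compound 3, `COC(=O)[C@@]1(C)CCC=C2[C@@H]1CC[C@@H](C)[C@]2(C)Cc1c[nH]c2c(Br)cccc12`, gives 14000 nM

Compound 2 differs from compound 1 by chloro in place of bromo on an aromatic carbon, and the step is a 1.1-fold lower number from compound 1 to compound 2 (0.04 log units; within the scatter). Compound 3 has the same atoms as compound 1, joined differently; the difference between the two cores is not broken down here. Against compound 1 and compound 2, compound 3 stands within the scatter of both.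

Compound 4, `COC(=O)[C@@]1(C)CCC=C2[C@@H]1CC[C@@H](C)[C@]2(C)Cc1c[nH]c2c(Cl)cccc12`, is not yet measured in this assay. It differs from compound 3 by chloro in place of bromo on an aromatic carbon. Among the compounds with values here, this is the same kind of change as the one from compound 1 to compound 2, but not the same: in the earlier pair the site is meta to a fused ring and para to a fused ring, whereas here it is ortho to a fused ring and meta to a fused ring. The expectation rests on the small size of a 1.1-fold lower number from compound 1 to compound 2 (0.04 log units; within the scatter) and on the value of compound 3, 14000 nM. Compound 4 is therefore expected to give 13000 nM in this assay, with a likely range from 7000 nM to 25000 nM. For compound 4 this means an expected step of a 1.1-fold lower number from compound 3 to compound 4 (0.03 log units; within the scatter).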

Compound 4, concentration for 50% growth inhibition: 14000 nM
Compound 4: middle estimate off by 1.1-fold (0.03 log units), on the low side; the range from low to high includes it.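

The new step in this assay is no change at the digits printed from compound 3 to compound 4 (within the scatter). Set beside the earlier step, chloro in place of bromo reads the same on both cores: the same change on two cores in this assay, a 1.1-fold lower number (0.04 log units; within the scatter) from compound 1 to compound 2 and no change at the digits printed (within the scatter) from compound 3 to compound 4, 1.1-fold (0.04 log units) apart, within the scatter of two such steps. This shows that, for these two halogens, the exchange carries from one core to the other with no readable difference in this assay, but it does not show that the halogen plays no part in growth inhibition, and a small real difference could lie hidden within the scatter of either step.

Both steps exchange one halogen for another, so the compounds shown say nothing about how far the number depends on having a halogen on the aromatic ring at all. On these data alone, whether an amine or a carboxylic acid in place of the halogen would move the number remains open, as does the effect of a carboxylic acid in place of the methyl ester on the shared core.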